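Chloro on the core of compound 1

The source may report more compounds than this note shows. Statements on the series, on what has been measured and on what is new or still open speak of the compounds shown alone.

Measured in a functional assay on the whole organism with Mus musculus as the target; on this read-out lower numbers stand for an effect already at smaller amounts and higher numbers for an effect only at larger amounts of compound:
- compound 1 `c1ccn(Nc2ccncc2)c1` gives > 20 mg/kg
- compound 2 `CCN(c1ccncc1)n1cccc1` gives > 20 mg/kg
- compound 3 `C=CCN(c1ccncc1)n1cccc1` gives > 20 mg/kg

Compound 1 stands at > 20 mg/kg, which is a limit and not a number. The same holds across the series, with the limit of > 20 mg/kg in this assay, at which 3 of the 3 values shown sit. Compound 4 `Clc1cccn1Nc1ccncc1` differs from compound 1 by one change, (chloro in place of hydrogen on an aromatic carbon), that is, chloro in place of hydrogen on an aromatic carbon. The measured steps, a step that the two limits leave unreadable from compound 1 to compound 2 and a step that the two limits leave unreadable from compound 1 to compound 3, concern a different place, and neither has a size that could be carried over. No shift beyond the scatter, in either direction, is therefore expected in this assay. The expected step is a number no higher from compound 1 to compound 4 (the limit leaves the size open). For compound 4 the estimated value is 20 mg/kg. The expected range runs from 8 mg/kg to 40 mg/kg.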

Compound 4, dose for half-maximal effect: > 20 mg/kg
Compound 4 was reported as a limit; the forecaster's own chance of this, stated with the estimate: 60%; the middle value lies on the limit itself.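

For the compounds shown here, compound 1 and compound 4 both stand at a limit, so no step between them can be read: the limit of > 20 mg/kg in this assay, at which 4 of the 4 values shown sit. The compounds shown leave open what dose of any of them would give a half-maximal effect in this assay.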